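This account rests on a few compounds, and the source may have more. Where it says the series, first, only, none or still open, it means among the compounds named here.

Working notes on the series. Going by the values given here, in a functional assay on SKW3 cells (Homo sapiens) for antiproliferative activity, read by WST assay, with a stated time of 3 days (a higher number here means a weaker inhibitor, a lower number a stronger inhibitor), compound 1 `[N-]=[N+]=Nc1c(F)c(=O)[nH]c(=O)n1[C@@H]1O[C@H](CO)[C@@H](O)[C@H]1O` gives 400 nM and compound 2 `Nc1c(F)c(=O)[nH]c(=O)n1[C@@H]1O[C@H](CO)[C@@H](O)[C@H]1O` gives 600 nM, so compound 2 stands within the scatter of the only other number available. Compound 3 `CCc1c(F)c(=O)[nH]c(=O)n1[C@@H]1O[C@H](CO)[C@@H](O)[C@H]1O` differs from compound 2 by ethyl in place of amino on an aromatic carbon. Among the compounds with values here, the one measured step bearing on this, a 1.5-fold higher number from compound 1 to compound 2 (0.18 log units; within the scatter), exchanged azido for amino at the same carbon and stayed small. It does not show how a carbon chain behaves there, so it offers only weak guidance, and the range must stay wide. A move to a higher number in this assay is expected, since ethyl resembles neither tested group. The estimated change is a 5.0-fold higher number from compound 2 to compound 3 (0.70 log units; beyond the scatter), towards a weaker inhibitor. For compound 3 the estimate is 3000 nM, with an expected range of 500 nM to 20000 nM.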

Compound 3, half-maximal inhibitory concentration: 1200 nM
Beside the measured number, compound 3's estimate is 2.5-fold (0.40 log units) above it, and the stated range covers the measured number.
By their numbers in this assay, from the lowest: compounds 1, 2 and 3 (each within the scatter of the next, the first and the last beyond it).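

In this assay the aromatic carbon next to the ring nitrogen and ortho to a fluoro group accepts a carbon chain as well as a nitrogen group: ethyl for amino gives a 2.0-fold higher number from compound 2 to compound 3 (0.30 log units; within the scatter) even though ethyl has 0 hydrogen-bond donors and 0 hydrogen-bond acceptors, against 1 of each for amino. Only the exchange of azido for ethyl separates clearly, with a 3.0-fold higher number from compound 1 to compound 3 (0.48 log units; beyond the scatter) as a modest step, so the three groups span a narrow band in which only the two ends lie apart. No measurement on hand explains these small differences.

The compounds shown leave open how a methyl group, a propyl chain or a carboxylic acid would read at this carbon. They also leave open whether ethyl would behave the same way with hydrogen in place of the fluoro group.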